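Propoxy in place of allyloxy on a weak pyridyl benzamide

The source may hold more compounds than are shown below. What is called first, only, known or untested is meant among the compounds shown, and "the series" means these compounds.

Measured so far:
compound 1, `CCCOc1ccc(C(=O)Nc2cccc(C)n2)cc1`, 11100 nM
compound 2, `C=CCOc1ccc(C(=O)Nc2cccc(Br)n2)cc1`, 65500 nM

In an in vitro assay on HEK-tsA201 cells for antagonist activity at Neuronal acetylcholine receptor; alpha3/beta4 (Homo sapiens), read by fluorescence and calcium flux (a lower number here means a stronger inhibitor, a higher number a weaker inhibitor), compound 2 gives 65500 nM, the higher of the two numbers recorded. Among the compounds with values here, its only neighbour is compound 1, whose value of 11100 nM sits well outside the scatter, though the two compounds differ in more than one place and no single step between them is given.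

Compound 3, `CCCOc1ccc(C(=O)Nc2cccc(Br)n2)cc1`, has not yet been measured. It differs from compound 2 by ethyl in place of vinyl on a saturated chain carbon bound to an oxygen on an aromatic ring. Within the data shown here, no measured pair isolates this change. On the two values known, the author expects the step from compound 2 to compound 3 in this assay to be small, either direction, and likely within the scatter, a 1.3-fold lower number from compound 2 to compound 3 (0.12 log units; within the scatter). Compound 3 is therefore estimated at 50000 nM, with a plausible range from 20000 nM to 130000 nM.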

Compound 3, half-maximal inhibitory concentration: > 100000 nM
Compound 3: no number, only a limit; the forecaster's own chance of this, stated with the estimate: 20%; at least 2.0-fold (0.30 log units) between middle value and limit.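

In this assay compound 3 returns a limit of the assay and not a number: the limit of > 100000 nM in this assay, at which 1 of the 3 values shown sits.

Even so, the limit allows the first comparisons between compounds that differ in one place. Allyl to propyl on the bromo compounds gives an at least 1.5-fold higher number from compound 2 to compound 3 (0.18 log units; that floor lies within the scatter), so this change cannot be said to separate the two compounds. With propoxy held constant, bromo in place of methyl on an aromatic carbon gives an at least 9.0-fold higher number from compound 1 to compound 3 (0.95 log units; beyond the scatter), which shows that this swap weakens inhibition clearly and sets a minimum size for that loss.

As far as these compounds go, the full size of both steps stays open while compound 3 has only a limit. Also open, from the compounds shown here alone, are how a chloro or an amine on that aromatic carbon would read, and whether a longer chain in place of propyl would change the result.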